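Amide Replaced by Furanylmethyl Ester on a Shared Core

The compounds below may be only part of what the source reports. "The series", "measured", "known", "first", "only" and "open" are said of these compounds alone.

Among the measured compounds shown here, compound 1 `CCN(CC)C(=O)C1=C(c2ccc(Cl)c(Cl)c2)CCC1` gives 94000 nM in an assay on COS-1 cells for displacement of a labelled ligand from sodium-dependent dopamine transporter (Homo sapiens) (a higher number here means a weaker inhibitor, a lower number a stronger inhibitor), the highest of the two numbers measured so far. Compound 2 `O=C(OCc1cccs1)C1=C(c2ccc(Cl)c(Cl)c2)CCC1` differs only at the carbonyl carbon, and in this assay compound 2 gives 400 nM, so that change brought a 240-fold lower number from compound 1 to compound 2 (2.37 log units; beyond the scatter). Compound 3 `O=C(OCc1ccco1)C1=C(c2ccc(Cl)c(Cl)c2)CCC1` carries a closely related group there: (furan-2-yl)methoxy in place of diethylamino on a carbonyl carbon. Because the step of a 240-fold lower number from compound 1 to compound 2 (2.37 log units; beyond the scatter) was so large, a comparably large drop is expected for compound 3, namely a 190-fold lower number from compound 1 to compound 3 (2.27 log units; beyond the scatter). Compound 3 is therefore estimated at 500 nM, within a range from 150 nM to 2000 nM.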

Compound 3, inhibition constant: 1500 nM
Estimate against measurement, compound 3: 3.0-fold (0.48 log units) below; low and high end bracket the measured number.
By their numbers in this assay, from the lowest: compound 2; then compound 3; then compound 1.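

In this assay, a second ester at this carbonyl carbon also gives a far lower number than the amide (a 63-fold lower number from compound 1 to compound 3 (1.80 log units; beyond the scatter)), so the large drop is not confined to the thiophen-2-yl ester. The ring on the ester still counts, as furan-2-yl in place of thiophen-2-yl gives a modest rise (a 3.8-fold higher number from compound 2 to compound 3 (0.57 log units; beyond the scatter)). No measured evidence here explains either step.

On these data alone, how a plain methoxy or a benzyloxy group would compare at this carbonyl carbon remains open. So does how much of the drop comes from the ester oxygen rather than the five-membered aromatic ring.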